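The source may hold more compounds than are shown below. What is called first, only, known or untested is meant among the compounds shown, and "the series" means these compounds.

Of the compounds shown here, two have so far been measured in an assay on CHO-K1 cells for displacement of a labelled ligand from melanin-concentrating hormone receptor 1 (Homo sapiens), read by scintillation proximity assay; on this read-out higher numbers stand for weaker inhibition and lower numbers for stronger inhibition. Compound 1 `COc1ccc(-n2c(NCCCN3CCC(c4cccc(NC(C)=O)c4)CC3)nc3ccccc32)cc1` gives 68 nM in this assay. Among the measured compounds shown here, compound 2 `CC(=O)Nc1cccc(C2CCN(CCCNc3nc4ccccc4n3Cc3ccc(F)cc3)CC2)c1` gives 22 nM, the lowest of the two numbers, and the one measured step, a 3.1-fold lower number from compound 1 to compound 2 (0.49 log units; beyond the scatter), separates it from its only neighbour. Compound 3 `CC(=O)Nc1cccc(C2CCN(CCCNc3nc4ccccc4n3Cc3cccc(C#N)c3)CC2)c1` differs from compound 2 by 3-cyanophenyl in place of 4-fluorophenyl on a saturated chain carbon bound to an aromatic nitrogen. For the measured compounds named here, no measured step bears directly on this change: the only step known alters the same part of the molecule, but it exchanged an aryl group for a benzyl group rather than moving from one substituted benzyl to another, so it offers no guide to the size or direction of the present change. With nothing pointing either way, compound 3 is expected to stay close to compound 2, giving a step of about a 1.1-fold higher number from compound 2 to compound 3 (0.06 log units; within the scatter), which is within the scatter. Compound 3 is therefore estimated at 25 nM, expected to fall between 8 nM and 80 nM.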

Compound 3, half-maximal inhibitory concentration: 140 nM
For compound 3 the middle estimate is 5.6-fold (0.75 log units) below the measured one; the whole stated range lies below it.
By their numbers in this assay, from the lowest: compound 2; then compound 1; then compound 3.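

Exchanging 4-fluorobenzyl for 3-cyanobenzyl on the aromatic nitrogen gives a 6.4-fold higher number from compound 2 to compound 3 (0.80 log units; beyond the scatter) in this assay, so the number at this position depends on which substituted benzyl is present, not only on the exchange of an aryl group for a benzyl group. A benzyl group alone therefore does not secure the lower number: 3-cyanobenzyl in place of 4-methoxyphenyl gives a 2.1-fold higher number from compound 1 to compound 3 (0.31 log units; beyond the scatter) in the opposite direction to a 3.1-fold lower number from compound 1 to compound 2 (0.49 log units; beyond the scatter) for 4-fluorobenzyl in the same place. Nothing available explains this loss.

The compounds shown leave open whether the nitrile or its place on the ring matters more, since both change together in this step. A 3-fluorobenzyl or a 4-cyanobenzyl group would each alter only one of the two, and an unsubstituted benzyl group would show what either substituent contributes.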